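This account rests on a few compounds, and the source may have more. Where it says the series, first, only, none or still open, it means among the compounds named here.

Three compounds share one core, which carries a phenyl group on the outer ring and a second aromatic group on the inner one. Compound 1 `Nc1nc(-c2ccccc2)nc2sc(-c3ccccc3)nc12` has an unsubstituted phenyl there and in an assay on CHO cells for displacement of a labelled ligand from adenosine receptor A1 (Homo sapiens), read by scintillation counting, with a stated time of 3 h (a higher number here means a weaker inhibitor, a lower number a stronger inhibitor), compound 1 gives 148 nM. Compound 2 `Nc1nc(-c2cccc(CO)c2)nc2sc(-c3ccccc3)nc12` gives 32 nM, and compound 3 `Nc1nc(-c2ccc(CO)cc2)nc2sc(-c3ccccc3)nc12` gives 82 nM. Adding a hydroxymethyl group gave a 4.6-fold lower number from compound 1 to compound 2 (0.67 log units; beyond the scatter) and a 1.8-fold lower number from compound 1 to compound 3 (0.26 log units; within the scatter), so only one of the two positions made a difference beyond the scatter, and between the two positions the step was a 2.6-fold higher number from compound 2 to compound 3 (0.41 log units; beyond the scatter).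

Compound 4 `COc1cccc(-c2nc(N)c3nc(-c4ccccc4)sc3n2)c1` differs from compound 3 in one place: 3-methoxyphenyl in place of 4-(hydroxymethyl)phenyl on an aromatic carbon. The move of the oxygen-bearing group back to the 3-position echoes the step of a 2.6-fold higher number from compound 2 to compound 3 (0.41 log units; beyond the scatter) in reverse, which would point toward a lower number. Among the measured compounds shown here, no measured pair shows what replacing hydroxymethyl with methoxy does, so that half of the change is unknown. Taken together, a lower number is expected for compound 4, a 1.6-fold lower number from compound 3 to compound 4 (0.21 log units; within the scatter), giving an estimated 50 nM with a range from 15 nM to 160 nM.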

Compound 4, inhibition constant: 176 nM
The estimate for compound 4 lay 3.5-fold (0.55 log units) below the measured number, and the stated range ends below it.
By their numbers in this assay, from the lowest: compound 2; then compounds 3, 1 and 4 (each within the scatter of the next, the first and the last beyond it).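

In this assay, exchanging hydroxymethyl for methoxy on the same phenyl group gives a 5.5-fold higher number from compound 2 to compound 4 (0.74 log units; beyond the scatter), so the lower number of compound 2 does not carry over to this other oxygen-bearing group. Compared with the unsubstituted phenyl, methoxy gives a 1.2-fold higher number from compound 1 to compound 4 (0.08 log units; within the scatter), and so offers no measurable gain. The change from 4-(hydroxymethyl)phenyl to 3-methoxyphenyl alters the group and its place at once and brings a 2.1-fold higher number from compound 3 to compound 4 (0.33 log units; beyond the scatter), which shows that 3-methoxyphenyl does not share the advantage that 3-(hydroxymethyl)phenyl holds over 4-(hydroxymethyl)phenyl.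

No evidence is available to explain the difference between hydroxymethyl and methoxy. The compounds shown leave open whether an aminomethyl group, a carboxylic acid or a longer hydroxyethyl chain in place of that hydroxymethyl would keep the lower number.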